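The source may hold more compounds than are shown below. What is called first, only, known or untested is meant among the compounds shown, and "the series" means these compounds.

Of the compounds shown here, two that share a core have been measured so far in a physicochemical assay for lipophilicity; a higher number here means a more lipophilic compound, a lower number a more polar compound. Compound 1 `CC(C)CN1C(=O)CN(Cc2ccc(-c3ccc(F)c(CN4CCCC(C)C4)n3)cc2)C1=O` gives 3.9, and compound 2 `O=C1CN(Cc2ccc(-c3ccc(F)c(CN4CCCCC4)n3)cc2)C(=O)N1CC1CC1` gives 2.8. Compound 2 therefore holds the lower of the two numbers, and the gap between them lies beyond the usual scatter of repeated measurements. Compound 3 `CC(C)CN1C(=O)CN(Cc2ccc(-c3ccc(F)c(CN4CCCCC4)n3)cc2)C1=O` has not yet been measured. It departs from compound 2 in one place: isopropyl in place of cyclopropyl on a saturated chain carbon bound to an amide-type nitrogen in a ring. In words, this is isopropyl in place of cyclopropyl on a saturated chain carbon bound to an amide-type nitrogen in a ring. Cut one bond further out, the same difference reads cyclopropylmethyl to isobutyl. Among the measured compounds shown here, no pair of measured compounds shows this change on its own, so the gap between compound 1 and compound 2 cannot be read as its size. For the measured compounds named here, with compound 1 at 3.9 as the highest number so far, a rise smaller than that gap is expected in this assay. The expected change is a number 0.50 log units higher from compound 2 to compound 3 (beyond the scatter). For compound 3 the estimate is 3.3, within an expected range from 3 to 3.7.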

Compound 3, distribution coefficient: 3.4
Beside the measured number, compound 3's estimate is 0.10 log units below it; the measured number falls inside the stated range.
By their numbers in this assay, from the lowest: compound 2; then compound 3; then compound 1.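

Measured by this assay the swap of cyclopropyl for isopropyl on a saturated chain carbon bound to an amide-type nitrogen in a ring gives a number 0.60 log units higher from compound 2 to compound 3 (beyond the scatter) and so now has a size of its own, although both groups hold the same count of 3 heavy atoms and only cyclopropyl holds a ring. Compound 3 also isolates the second difference between the two earlier compounds: hydrogen in place of methyl on a saturated ring carbon gives a number 0.50 log units lower from compound 1 to compound 3 (beyond the scatter) and this too lies beyond the usual scatter. The gap between compound 1 and compound 2 can therefore be read as two single changes rather than one unresolved difference, but nothing measured here explains why either change moves the number as it does.

The compounds shown leave open how a longer chain such as n-butyl, a cyclobutyl group or a chain carrying an ether oxygen would read at this position. They also leave open whether the isopropyl-for-cyclopropyl step keeps its size when the methyl group is present on the saturated ring carbon.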